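A few compounds are considered here, and "the series" means these few. Any claim that something is new, unique, unknown or untested is made for them only; others in the source may bear on it.

In a functional assay on CRL2813 cells (Homo sapiens) for cytotoxicity, read by sulforhodamine B assay, with a stated time of 5 days (a lower number here means a stronger inhibitor, a higher number a weaker inhibitor), three compounds built on one shared core have been measured, and each carries a different aryl group on an amide-type nitrogen. Compound 1 `O=C(Nc1cccc([N+](=O)[O-])c1)N[C@H]1CC[C@H](Oc2ccc(F)cc2)CC1` gives 6700 nM. Compound 2 `O=C(Nc1ccc(I)cc1)N[C@H]1CC[C@H](Oc2ccc(F)cc2)CC1` gives 10200 nM. Compound 3 `O=C(Nc1ccccc1Cl)N[C@H]1CC[C@H](Oc2ccc(F)cc2)CC1` gives 9100 nM, the second highest of the three numbers; its nearest neighbour is compound 2 and its furthest is compound 1, and both gaps lie within the scatter of repeated measurements, so none of the three can be set apart from the others.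

Compound 4 `O=C(Nc1cccc(I)c1)N[C@H]1CC[C@H](Oc2ccc(F)cc2)CC1` is not yet measured. It differs from compound 3 in one place: 3-iodophenyl in place of 2-chlorophenyl on an amide-type nitrogen.

Among the compounds with values here, three measured steps bear on this, since each of them exchanges the aryl group on the same nitrogen. There was a 1.4-fold higher number from compound 1 to compound 3 (0.13 log units; within the scatter), there was a 1.1-fold lower number from compound 2 to compound 3 (0.05 log units; within the scatter), and there was a 1.5-fold higher number from compound 1 to compound 2 (0.18 log units; within the scatter). All three are within the scatter. Nothing seen so far shows that changing this aryl group moves the number in this assay beyond the scatter, so for compound 4 no step beyond the scatter is expected in either direction, that is a 1.0-fold lower number from compound 3 to compound 4 (0.00 log units; within the scatter) is the expected step. Compound 4 is therefore estimated at 9000 nM, with a range from 4500 nM to 18000 nM.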

Compound 4, half-maximal inhibitory concentration: 5200 nM
Compound 4: the middle estimate sits 1.7-fold (0.24 log units) above what was measured; measured number inside the range.
By their numbers in this assay, from the lowest: compounds 4, 1, 3 and 2 (each within the scatter of the next).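

In this assay, within the data shown here, the new compound gives the first comparison of one halogen at two ring positions on this nitrogen: 3-iodophenyl in place of 4-iodophenyl gives a 2.0-fold lower number from compound 2 to compound 4 (0.29 log units; within the scatter) and so stays within the scatter, which means these data do not show that the position of the iodine matters here. The other two exchanges also stay within the scatter, with 3-iodophenyl in place of 2-chlorophenyl giving a 1.8-fold lower number from compound 3 to compound 4 (0.24 log units; within the scatter) and iodo in place of nitro on an aromatic carbon giving a 1.3-fold lower number from compound 1 to compound 4 (0.11 log units; within the scatter) as the result, so the four chloro-, iodo- and nitro-bearing aryl groups cannot be told apart in this assay. No accompanying measurement offers any explanation for the small differences between these compounds.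

All four groups shown are phenyl rings carrying a single substituent, so it remains open whether an amine or a carboxylic acid on that ring, or an unsubstituted phenyl, would move the number beyond the scatter. Going by these compounds, it is equally open whether a longer alkyl chain in place of the aryl group on this nitrogen would do so, or whether a change elsewhere on the shared core would.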